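Propanoyl to Acetyl: One More Trim

The source may hold more compounds than are shown below. What is called first, only, known or untested is meant among the compounds shown, and "the series" means these compounds.

Of the compounds shown here, three sharing one core have been tested in an ADME assay on HEK293 cells (Homo sapiens) for inhibition, read by MTT assay, with a stated time of 96 h; a lower number here means a stronger inhibitor of growth, a higher number a weaker inhibitor of growth. Compound 1 (`CC(C)C(=O)SCCCCCCNC(=O)c1cc(-c2ccncc2)n[nH]1`) gives > 50000 nM, which is a limit of the assay and not a number. Compound 2 (`CCCC(=O)SCCCCCCNC(=O)c1cc(-c2ccncc2)n[nH]1`) gives > 50000 nM, which is also a limit. Compound 3 (`CCC(=O)SCCCCCCNC(=O)c1cc(-c2ccncc2)n[nH]1`) gives > 50000 nM, again a limit. The whole set therefore sits at one boundary: the limit of > 50000 nM in this assay, at which 3 of the 3 values shown sit.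

Compound 4 (`CC(=O)SCCCCCCNC(=O)c1cc(-c2ccncc2)n[nH]1`) has not yet been measured. It differs from compound 3 by hydrogen in place of methyl on a saturated chain carbon bound to a carbonyl carbon, which is hydrogen in place of methyl on a saturated chain carbon bound to a carbonyl carbon, so propanoyl becomes acetyl.

Three measured steps on this same acyl group bear on the change: a step that the two limits leave unreadable from compound 1 to compound 2, a step that the two limits leave unreadable from compound 1 to compound 3 and a step that the two limits leave unreadable from compound 2 to compound 3. None has a readable size, so they point in no direction. The expected step is a number no higher from compound 3 to compound 4 (the limit leaves the size open), with no shift beyond the scatter anticipated. Compound 4 is estimated at 50000 nM, with an expected range from 20000 nM to 100000 nM.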

Compound 4, concentration for 50% growth inhibition: > 50000 nM
Compound 4 gave a limit, no number (the forecaster's own chance of this, stated with the estimate: 80%); the middle value sits exactly at the limit.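

In this assay compound 4 gives a limit and not a number, as do compound 1, compound 2 and compound 3, so no step among these four compounds can be read: the limit of > 50000 nM in this assay, at which 4 of the 4 values shown sit.

The compounds shown leave open how strongly any of them inhibits growth, and whether changing the acyl group alters that at all.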